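This account rests on a few compounds, and the source may have more. Where it says the series, first, only, none or still open, it means among the compounds named here.

Working notes on the series, read in a functional assay on cells (Homo sapiens) for cytotoxicity, read by MTT assay, with a stated time of 24 h; on this read-out higher numbers stand for weaker inhibition and lower numbers for stronger inhibition. Compound 1 `CCCCCCCCCCCCCCNC(=O)[C@H](CO)/N=C/c1ccccc1OC` gives 12500 nM, compound 2 `CCCCCCCCCCCCCCNC(=O)[C@H](CO)/N=C/c1ccccc1Cl` gives 10300 nM and compound 3 `CCCCCCCCCCCCCCNC(=O)[C@H](CO)/N=C/c1ccccc1` gives 7670 nM. Compound 3 stands in one band with the other two, since its steps to both remain within the scatter, and no order can be read among the three.

Compound 4 `CCCCCCCCCCCCCCNC(=O)[C@H](CO)/N=C/c1ccccc1C` differs from compound 3 by one change: methyl in place of hydrogen on an aromatic carbon, ortho to a large group.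

Within the data shown here, two measured steps bear on this place, each putting hydrogen in place of another group: a 1.3-fold lower number from compound 2 to compound 3 (0.13 log units; within the scatter) and a 1.6-fold lower number from compound 1 to compound 3 (0.21 log units; within the scatter). The step between the two substituted compounds, a 1.2-fold lower number from compound 1 to compound 2 (0.08 log units; within the scatter), adds the same picture. All three stay within the scatter, so compound 1 and compound 2 show no sensitivity to the group at this place that could be told from noise. Among the measured compounds shown here, no methyl compound has yet been measured, and the expectation rests on these three steps alone.

In this assay no step beyond the scatter is expected, and the estimated step is a 1.2-fold higher number from compound 3 to compound 4 (0.07 log units; within the scatter). Compound 4 is estimated at 9000 nM, with an expected range from 5000 nM to 16000 nM.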

Compound 4, half-maximal inhibitory concentration: 87700 nM
Beside the measured number, compound 4's estimate is 9.7-fold (0.99 log units) below it; measured number outside the range, above it.
By their numbers in this assay, from the lowest: compounds 3, 2 and 1 (each within the scatter of the next); then compound 4.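

In this assay, among these compounds, this position, on an aromatic carbon ortho to a large group, turns out not to be indifferent to what sits there: the earlier compounds gave no step beyond the scatter, whereas methyl gives an 11-fold higher number from compound 3 to compound 4 (1.06 log units; beyond the scatter), and so moves toward weaker inhibition. The same separation holds against the two other substituted compounds, with an 8.5-fold higher number from compound 2 to compound 4 (0.93 log units; beyond the scatter) and a 7.0-fold higher number from compound 1 to compound 4 (0.85 log units; beyond the scatter), so compound 4 stands alone while compounds 1, 2 and 3 remain in one band. Carrying a substituent here is therefore not enough to produce the shift, since chloro in compound 2 and methoxy in compound 1 stay within the scatter of hydrogen in compound 3, and nothing at hand accounts for why methyl alone parts from them.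

On these data alone, it remains open whether the shift belongs to methyl only or extends to other carbon-based groups at this place, such as ethyl or trifluoromethyl. Also open, as far as these compounds go, is whether an amine or a hydroxyl group here would fall with compound 4 or with the band of compounds 1, 2 and 3.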